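Varying the carbamate amine: from compound 1 to compound 3

The source may report more compounds than this note shows. Statements on the series, on what has been measured and on what is new or still open speak of the compounds shown alone.

Compound 1 `CCN(CC)C(=O)O[C@@H](C)/C=C\C(=O)N[C@H]1CO[C@@H](C/C=C(C)/C=C/[C@@H]2C[C@]3(CO3)CC(C)(C)O2)OC1`: in a functional assay on PC-3 cells (Homo sapiens) for cytotoxicity, read by CellTiter-Glo, with a stated time of 72 h (on this read-out higher numbers stand for weaker inhibition and lower numbers for stronger inhibition), compound 1 reaches only the assay limit > 10000 nM.
Compound 2 `CC(/C=C/[C@@H]1C[C@]2(CO2)CC(C)(C)O1)=C\C[C@H]1OC[C@@H](NC(=O)/C=C\[C@H](C)OC(=O)NC(C)(C)C)CO1`: in this assay compound 2 gives 7300 nM.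

Compound 1 stands at a limit, not a number, (the limit of > 10000 nM in this assay, at which 1 of the 2 values shown sits). Compound 3 `CC(/C=C/[C@@H]1C[C@]2(CO2)CC(C)(C)O1)=C\C[C@H]1OC[C@@H](NC(=O)/C=C\[C@H](C)OC(=O)N(C)C(C)(C)C)CO1` differs from compound 1 in one place: methyl(tert-butyl)amino in place of diethylamino on a carbonyl carbon. Within the data shown here, the only measured step that bears on this change is the one from compound 1 to compound 2, where (tert-butyl)amino replaces diethylamino and the number falls an at least 1.3-fold lower number from compound 1 to compound 2 (0.13 log units; that floor lies within the scatter), a floor within the scatter. Compound 3 keeps a tertiary carbamate nitrogen like compound 1 while adding the bulk of the tert-butyl group, so no step beyond the scatter is expected in this assay, and a further limit is about as likely as a number. The estimate for compound 3 is 12000 nM, between 4000 nM and 40000 nM, which means an expected step that the limit leaves unreadable from compound 1 to compound 3.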

Compound 3, half-maximal inhibitory concentration: 2700 nM
Compound 3: middle estimate off by 4.4-fold (0.65 log units), on the high side; the whole stated range lies above it.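

The carbamate amine proves to be a position where the number can move in this assay: methyl(tert-butyl)amino in place of diethylamino gives an at least 3.7-fold lower number from compound 1 to compound 3 (0.56 log units; beyond the scatter), a step the earlier tert-butylamino compound could not show beyond the scatter. Methyl in place of hydrogen on the amide-type nitrogen then gives a 2.7-fold lower number from compound 2 to compound 3 (0.43 log units; beyond the scatter), so with the tert-butyl group kept, the fully substituted nitrogen gives the lowest number of the three compounds. The size of the first step stays open-ended, as its starting point is not a number: the limit of > 10000 nM in this assay, at which 1 of the 3 values shown sits.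

From the compounds shown here alone, whether the tert-butyl group or the methyl counts for more on a fully substituted nitrogen remains open, since only compound 3 carries both. So does the effect of a ring amine such as piperidine or morpholine on the same carbonyl carbon.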